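Chloroamide series: replacing chloropyridine with chlorothiazole

The compounds below may be only part of what the source reports. "The series", "measured", "known", "first", "only" and "open" are said of these compounds alone.

For the measured compounds named here, compound 1 `O=C(CCl)Nc1cccc(-c2nc3ccccc3s2)c1` is the only member of this small set with a number rather than a limit in an ADME assay on HEK293 cells (Homo sapiens) for inhibition, with a stated time of 72 h; a higher number here means that more compound is needed for the effect, a lower number that less compound is needed: compound 1 gives 10000 nM. Compound 2 `O=C(Nc1cccc(-c2nc3ccccc3s2)c1)c1ccnc(Cl)c1` returns a limit in this assay, compound 2 giving > 25000 nM. Compound 3 `O=C(Nc1cccc(-c2nc3ccccc3s2)c1)c1ccncc1Cl` also returns a limit, compound 3 giving > 25000 nM. The steps from the chloromethyl parent are an at least 2.5-fold higher number from compound 1 to compound 2 (0.39 log units; beyond the scatter) and an at least 2.5-fold higher number from compound 1 to compound 3 (0.39 log units; beyond the scatter), while a step that the two limits leave unreadable from compound 2 to compound 3. Both aryl analogues sit at the limit of > 25000 nM in this assay, at which 2 of the 3 values shown sit, so compound 3 stands at the top of what the assay reports.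

Compound 4 `O=C(Nc1cccc(-c2nc3ccccc3s2)c1)c1cnc(Cl)s1` differs from compound 3 by 2-chloro-1,3-thiazol-5-yl in place of 3-chloropyridin-4-yl on a carbonyl carbon. Both measured steps that bear on this position, from compound 1 to compound 2 and from compound 1 to compound 3, show that an aryl group on the carbonyl carbon drives the number to the limit, and the swap between the two chloropyridines left nothing readable. The expected outcome for compound 4 is therefore another limit, with no readable movement, an estimate of a number no higher from compound 3 to compound 4 (the limit leaves the size open). Compound 4 is thus estimated at 25000 nM, with a range from 6000 nM to 80000 nM.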

Compound 4, half-maximal effective concentration: > 25000 nM
Compound 4 was reported as a limit (the forecaster's own chance of this, stated with the estimate: 65%); the middle value sits exactly at the limit.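

On the carbonyl carbon, the 2-chloro-1,3-thiazol-5-yl group, a five-membered aromatic ring with 2 hetero atoms, behaves in this assay as the two chloropyridines do, with an at least 2.5-fold higher number from compound 1 to compound 4 (0.39 log units; beyond the scatter). The rise from the chloromethyl compound is therefore not confined to a six-membered aromatic ring at this position. The steps among compound 2, compound 3 and compound 4 cannot be read, so no order among the three aromatic groups can be given, and the series shows only a shared ceiling: the limit of > 25000 nM in this assay, at which 3 of the 4 values shown sit.

As far as these compounds go, how far the three aromatic groups lie above that limit remains open. Also open, from the compounds shown here alone, is whether the lower number of compound 1 depends on the chlorine of its chloromethyl group, a question that a plain methyl or a dimethylaminomethyl group on the carbonyl carbon would address.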